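The source may report more compounds than this note shows. Statements on the series, on what has been measured and on what is new or still open speak of the compounds shown alone.

In a functional assay on MCF7 cells (Homo sapiens) for cytotoxicity, read by sulforhodamine B assay, with a stated time of 48 h, in the presence of a further agent that is not named here (a lower number here means a stronger inhibitor of growth, a higher number a weaker inhibitor of growth), compound 1 (`Cc1nn(-c2ccccc2)c(Oc2ccc(-c3nc4cc([N+](=O)[O-])ccc4[nH]3)cc2)c1/C=N/NC(N)=S`) gives > 100000 nM, which is a limit of the assay. Within the data shown here, compound 2 (`Cc1nn(-c2ccccc2)c(Oc2ccc(-c3nc4cc(C(=O)O)ccc4[nH]3)cc2)c1/C=N/Nc1ccccc1`) gives 90 nM, the only actual number so far. Compound 3 (`COc1ccc(N/N=C/c2c(C)nn(-c3ccccc3)c2Oc2ccc(-c3nc4cc(C(N)=O)ccc4[nH]3)cc2)cc1`) gives > 100000 nM, again only a limit. That places it at the limit of > 100000 nM in this assay, at which 2 of the 3 values shown sit.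

Compound 4 (`Cc1nn(-c2ccccc2)c(Oc2ccc(-c3nc4cc(C(N)=O)ccc4[nH]3)cc2)c1/C=N/NC(N)=O`) carries carbamoyl in place of 4-methoxyphenyl on an amine nitrogen. Among the measured compounds shown here, no measured pair tests this change. The expectation of little movement rests on compound 3, whose limit is > 100000 nM. Compound 2 at 90 nM leaves a stronger reading possible. In this assay the expected step, if one can be read at all, is toward stronger inhibition and modest: an at least 2.0-fold lower number from compound 3 to compound 4 (0.30 log units; that floor lies within the scatter). The estimated value for compound 4 is 50000 nM, with an expected range of 500 nM to 150000 nM.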

Compound 4, concentration for 50% growth inhibition: > 100000 nM
Compound 4 ended at the assay's limit (the forecaster's own chance of this, stated with the estimate: 60%); at least 2.0-fold (0.30 log units) between middle value and limit.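

Compound 3 and compound 4 both end at a limit in this assay, so no step can be read between them: the limit of > 100000 nM in this assay, at which 3 of the 4 values shown sit.

On these data alone, whether carbamoyl in place of 4-methoxyphenyl on an amine nitrogen changes growth inhibition in a compound with a measurable value stays open.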